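The source may hold more compounds than are shown below. What is called first, only, known or untested is meant among the compounds shown, and "the series" means these compounds.

Measured so far: compound 1 `Nc1nc(=O)ccn1[C@@H]1O[C@H](COP(=O)(O)OP(=O)(O)O)[C@@H](O)[C@H]1O`; compound 2 `CSc1nc(=O)ccn1[C@@H]1O[C@H](COP(=O)(O)OP(=O)(O)O)[C@@H](O)[C@H]1O`; compound 3 `Nc1nc(=O)ccn1[C@@H]1O[C@H](COP(=O)(O)O)[C@@H](O)[C@H]1O`.

In an in vitro functional assay on 1321-N1 cells for agonist activity at P2Y purinoceptor 6 (Homo sapiens), read by scintillation proximity assay and inositol phosphate accumulation (a lower number here means that less compound is needed, a higher number that more compound is needed for the effect), compound 1 gives >= 100000 nM, which is a limit of the assay. Compound 2 gives 4700 nM in this assay. Compound 3 gives > 100000 nM, again a limit and no number, so compound 3 stands at the limit of > 100000 nM in this assay, at which 1 of the 3 values shown sits, the least sensitive end of what has been measured.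

The next compound, compound 4 `COc1nc(=O)ccn1[C@@H]1O[C@H](COP(=O)(O)O)[C@@H](O)[C@H]1O`, carries methoxy in place of amino on an aromatic carbon. The step that bears on it is an at least 21-fold lower number from compound 1 to compound 2 (1.32 log units; beyond the scatter), made on the core of compound 1 with methylsulfanyl rather than methoxy; the step that the two limits leave unreadable from compound 1 to compound 3 gives no size. A smaller gain is therefore expected: the expected step is an at least 2.5-fold lower number from compound 3 to compound 4 (0.39 log units; beyond the scatter). Compound 4 is estimated at 40000 nM, with a range from 8000 nM to 200000 nM.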

Compound 4, half-maximal effective concentration: 9800 nM
Compound 4: middle estimate off by 4.1-fold (0.61 log units), on the high side; measured number inside the range.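

In this assay, methoxy in place of amino on the aromatic carbon between two ring nitrogen atoms gives an at least 10-fold lower number from compound 3 to compound 4 (1.00 log units; beyond the scatter). Leaving amino at this position therefore pays with an oxygen-linked group as well as with methylsulfanyl, and on the single-phosphate core as well as the diphosphate core. Compound 3 sits at a limit of the assay: the limit of > 100000 nM in this assay, at which 1 of the 4 values shown sits.

Compound 2 and compound 4 differ in two places, so methoxy and methylsulfanyl remain unranked on a single phosphate chain. Also open, as far as these compounds go, is how ethoxy or a methylamino group would fare at this position.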